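A few compounds are considered here, and "the series" means these few. Any claim that something is new, unique, unknown or untested is made for them only; others in the source may bear on it.

Measured so far:
Compound 1, `CC(=O)N[C@@H]1CCC[C@H](C(=O)Nc2cc(-c3cnn4c3CC(C)(C)C4)c(F)cn2)C1`: 2.6 uL/min
Compound 2, `CC(=O)N[C@@H]1CCC[C@H](C(=O)Nc2cc(-c3cnn4c3CC(C)(C)C4)c(Cl)cn2)C1`: 3.5 uL/min

Both compounds were tested in an ADME assay on cells (Hepatocyte, Homo sapiens) for metabolic stability, using equilibrium dialysis; a higher number here means faster removal of the compound, a lower number slower removal. Compound 2 differs from compound 1 only by a chloro in place of a fluoro on an aromatic carbon, and the result moved by a 1.3-fold higher number from compound 1 to compound 2 (0.13 log units; within the scatter), so the two numbers cannot be told apart; compound 2 stands level with compound 1 on the evidence available.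

Compound 3, `CC(=O)N[C@@H]1CC[C@H](C(=O)Nc2cc(-c3cnn4c3CC(C)(C)C4)c(Cl)cn2)C1`, differs from compound 2 in one place: 3-acetamidocyclopentyl in place of 3-acetamidocyclohexyl on a carbonyl carbon. The ring that carries the acetamido group and the carbonyl carbon shrinks by one carbon while the rest of the molecule is unchanged.

Going by the values given here, no measured step speaks to this kind of change. Among the compounds with values here, the only step in hand, a 1.3-fold higher number from compound 1 to compound 2 (0.13 log units; within the scatter), concerns a halogen on an aromatic carbon, far from the carbonyl carbon, and it was itself within the scatter. With nothing pointing either way, the expected step is no change at the digits printed from compound 2 to compound 3 (within the scatter), that is, nothing beyond the scatter. For compound 3 the estimate in this assay is 3.5 uL/min, with a range from 1.5 uL/min to 8 uL/min.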

Compound 3, intrinsic clearance in a liver preparation (reported as CLH), per the amount of preparation that the assay uses: 5.8 uL/min
Estimate against measurement, compound 3: 1.7-fold (0.22 log units) below, within the range that was stated.
By their numbers in this assay, from the lowest: compounds 1, 2 and 3 (each within the scatter of the next, the first and the last beyond it).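

Going by these compounds alone, this pair gives the first reading on the ring attached to the carbonyl carbon, a different part of the molecule from the halogen on the aromatic carbon. In this assay, 3-acetamidocyclopentyl in place of 3-acetamidocyclohexyl gives a 1.7-fold higher number from compound 2 to compound 3 (0.22 log units; within the scatter), so taking one carbon out of this ring, with the acetamido group and the rest of the molecule kept, leaves compound 2 and compound 3 indistinguishable in this measurement. Nothing available on these compounds bears on why the step has this size.

Open, going by these compounds, is whether this tolerance holds when the acetamido group itself is replaced, for example by an amine or a carboxylic acid, or when the ring on the carbonyl carbon becomes a four-membered ring of carbon only. Also open, on these data alone, is whether the same ring change would give a similar step in the fluoro compound, since this single pair carries chloro on the aromatic carbon and cannot show whether the result extends beyond it.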